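The source may hold more compounds than are shown below. What is called first, only, known or untested is meant among the compounds shown, and "the series" means these compounds.

Measured so far in a functional assay on KB 3-1 cells (Homo sapiens) for cytotoxicity, read by MTT assay, with a stated time of 68 h; on this read-out higher numbers stand for weaker inhibition and lower numbers for stronger inhibition:

Compound 1 `O=C(Nc1cccc(-c2ccc(F)cc2)c1)C(Cl)Cl`: 26200 nM
Compound 2 `O=C(Nc1cccc(-c2ccccc2)c1)C(Cl)Cl`: 46800 nM

Going by the values given here, compound 2, at 46800 nM, lies within the usual scatter of compound 1, the only other compound with a number, so these two values cannot be ranked. Compound 3 `COC(=O)c1ccc(-c2cccc(NC(=O)C(Cl)Cl)c2)cc1` is the next to be considered. It differs from compound 2 in one place: methoxycarbonyl in place of hydrogen on an aromatic carbon. In words, this is methoxycarbonyl in place of hydrogen on an aromatic carbon, para to a large group.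

Among the compounds with values here, only one measured step bears on this change. It is also a swap on an aromatic carbon, hydrogen in place of fluoro: a 1.8-fold higher number from compound 1 to compound 2 (0.25 log units; within the scatter). Within the data shown here, that step stayed within the scatter, but no measured compound carries methoxycarbonyl, so it is only a weak guide. In this assay no step beyond the scatter is therefore expected, and the data favour no direction. The expected change is a 1.3-fold lower number from compound 2 to compound 3 (0.13 log units; within the scatter). For compound 3 the estimated value is 35000 nM, with an expected range from 12000 nM to 90000 nM.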

Compound 3, half-maximal inhibitory concentration: > 50000 nM
Compound 3: only a limit was reported (the forecaster's own chance of this, stated with the estimate: 10%); middle value at least 1.4-fold (0.15 log units) from the limit.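

In this assay compound 3 gives > 50000 nM, which is a limit and not a measured number. Read as a floor, the change at this position gives an at least 1.0-fold higher number from compound 2 to compound 3 (0.02 log units; that floor lies within the scatter), and the swap against the fluoro compound gives an at least 1.9-fold higher number from compound 1 to compound 3 (0.28 log units; that floor lies within the scatter); since both floors lie within the scatter, neither step can be called a real loss of inhibition, and its true size remains unknown. What is new is that methoxycarbonyl, with its 4 heavy atoms and 2 hydrogen-bond acceptors, brings the number no lower than those of the smaller fluoro and hydrogen compounds, although how much higher it lies cannot be read: the limit of > 50000 nM in this assay, at which 1 of the 3 values shown sits.

The compounds shown leave open whether an amine, a carboxylic acid or a longer chain in the same place would give a number that can be read, and in which direction it would move. Going by these compounds alone, with only three compounds, one of them a limit, no trend at this position can yet be claimed.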